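Saturating the vinyl group: from compound 2 to compound 3

The compounds below may be only part of what the source reports. "The series", "measured", "known", "first", "only" and "open" are said of these compounds alone.

Of the compounds shown here, two sharing one core have been measured in an assay on HEK293 cells for inhibition of transient receptor potential cation channel subfamily V member 1 (Homo sapiens); on this read-out lower numbers stand for stronger inhibition and higher numbers for weaker inhibition. Compound 1 `CCCCCCCCC(=O)NCc1cc(Cl)c(O)c(OC)c1` gives 631 nM. Compound 2 `C=Cc1cc(CNC(=O)CCCCCCCC)cc(OC)c1O` gives 390 nM. Within the data shown here, the only measured step, a 1.6-fold lower number from compound 1 to compound 2 (0.21 log units; within the scatter), so the two numbers are not distinguishable and compound 2 stands alongside compound 1 rather than apart from it.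

Compound 3 `CCCCCCCCC(=O)NCc1cc(CC)c(O)c(OC)c1` differs from compound 2 in one place: ethyl in place of vinyl on an aromatic carbon. Among the measured compounds shown here, no measured step touches this particular exchange; the one step in hand concerns a different group entering the same position, and it stayed within the scatter. Nothing in the data therefore points to a change beyond the scatter in this assay, in either direction, and the expectation for compound 3 is a number close to that of compound 2. The estimated step is a 1.0-fold higher number from compound 2 to compound 3 (0.01 log units; within the scatter). Compound 3 is accordingly expected to give about 400 nM, with a range from 180 nM to 900 nM.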

Compound 3, half-maximal inhibitory concentration: 355 nM
Compound 3: middle estimate off by 1.1-fold (0.05 log units), on the high side; low and high end bracket the measured number.
By their numbers in this assay, from the lowest: compounds 3, 2 and 1 (each within the scatter of the next).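

Swapping vinyl for ethyl, which removes the one double bond outside the aromatic ring, leaves no readable difference in this assay, with a 1.1-fold lower number from compound 2 to compound 3 (0.04 log units; within the scatter) as the step. Ethyl also stays within the scatter of chloro, with a 1.8-fold lower number from compound 1 to compound 3 (0.25 log units; within the scatter) as the step, so this aromatic carbon, ortho to a hydroxy group, has now carried three different groups, and these three compounds cannot be told apart on this read-out. Nothing measured here explains why these exchanges leave the numbers so close.

All three groups are small and have no hydrogen-bond donors or acceptors under the computed comparisons available for vinyl and ethyl. Going by these compounds, what remains open is whether an amine, a carboxylic acid or a longer chain such as hexyl at this position would stay within the scatter too.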